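This account rests on a few compounds, and the source may have more. Where it says the series, first, only, none or still open, it means among the compounds named here.

In an assay on membranes from liver for displacement of a labelled ligand from Glucagon receptor (Mus musculus), read by scintillation counting, with a stated time of 60 min (a higher number here means a weaker inhibitor, a lower number a stronger inhibitor), compound 1 `CC(C)(C)CC[C@H](c1ccc(C(=O)NCc2nn[nH]n2)cc1)N1C(=O)C(c2cncc(Cl)c2)=N[C@]12CC[C@@H](C(C)(C)C)CC2` gives 84 nM, the lower of the two numbers reported in this assay. The nearest measured compound, compound 3 `CCCCC[C@H](c1ccc(C(=O)NCc2nn[nH]n2)cc1)N1C(=O)C(c2cc(Cl)cc(Cl)c2)=N[C@]12CC[C@@H](C(C)(C)C)CC2`, gives 310 nM in this assay, a gap beyond the usual scatter. Compound 2 `C[C@H](c1ccc(C(=O)NCCC(=O)O)cc1)N1C(=O)C(c2ccccc2F)=N[C@]12CC[C@@H](C(C)(C)C)CC2` reaches only a limit of the assay, > 10000 nM, rather than a number. For the measured compounds named here, the set thus contains one result that is only a limit (the limit of > 10000 nM in this assay, at which 1 of the 3 values shown sits), so the comparison rests on the two numbered values alone; no pair among the measured compounds differs in a single place, so no measured step is available.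

Compound 4 `CC(C)(C)CC[C@H](c1ccc(C(=O)NCc2nn[nH]n2)cc1)N1C(=O)C(c2cnccc2C(F)(F)F)=N[C@]12CC[C@@H](C(C)(C)C)CC2` is the next compound to be measured in this assay. It differs from compound 1 in one place: 4-(trifluoromethyl)pyridin-3-yl in place of 5-chloropyridin-3-yl on a carbon with a double bond to nitrogen. The change keeps the hydrogen-bond acceptor count and the charge unchanged while the group grows by three heavy atoms. Going by the values given here, with no measured step between compounds of this set to lean on, the expected step from compound 1 to compound 4 is a modest one, at the edge of the scatter and probably toward a higher number, which is to say estimated at a 1.8-fold higher number from compound 1 to compound 4 (0.25 log units; within the scatter). Compound 4 is therefore expected to give about 150 nM in this assay, with a range estimated from 50 nM to 600 nM.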

Compound 4, half-maximal inhibitory concentration: 96 nM
Compound 4: the middle estimate sits 1.6-fold (0.19 log units) above what was measured; the measured number falls inside the stated range.
By their numbers in this assay, from the lowest: compounds 1 and 4 (each within the scatter of the next); then compound 3. At a limit, above all of these: compound 2.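

In this assay, for the compounds shown here, the set now has its first measured step, a 1.1-fold higher number from compound 1 to compound 4 (0.06 log units; within the scatter), and it gives the first direct reading at this position, on a carbon with a double bond to nitrogen. It shows that 4-(trifluoromethyl)pyridin-3-yl, with 10 heavy atoms, can take the place of 5-chloropyridin-3-yl, with 7, without a change that can be told from the scatter, even though chlorine leaves, three fluorines enter, and the two groups carry their substituents at different ring positions. Going by these compounds alone, nothing measured here gives a reason for this result, and the step alone shows only that these two groups cannot be told apart in this assay.

The compounds shown leave open whether the position would tolerate groups of another kind, such as a plain phenyl ring, a pyridine ring bearing a nitrile or an amine, or a small methyl group in place of the ring. They also leave open whether 4-(trifluoromethyl)pyridin-3-yl would give a matching step on the longer chain that compound 3 carries.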